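Trading a Branched Alkyl for an Amide-Bearing Chain

The source may report more compounds than this note shows. Statements on the series, on what has been measured and on what is new or still open speak of the compounds shown alone.

Of the compounds shown here, two have been measured in an assay on isolated protein for inhibition of serine protease 1 (Bos taurus); a lower number here means a stronger inhibitor, a higher number a weaker inhibitor. Compound 1 `CC(=N)N1CCC(Oc2ccc3nc(C(C)C)n(Cc4ccc5ccc(C(=N)N)cc5c4)c3c2)CC1` gives 5.7 nM in this assay, and compound 2 `CCC(C)c1nc2ccc(OC3CCN(C(C)=N)CC3)cc2n1Cc1ccc2ccc(C(=N)N)cc2c1` gives 10 nM. Compound 2 shows the higher of the two numbers, yet the difference a 1.8-fold higher number from compound 1 to compound 2 (0.24 log units; within the scatter) is small and within the scatter, so the two compounds are not distinguishable in this assay. Compound 3 `CC(=N)N1CCC(Oc2ccc3nc(CCC(N)=O)n(Cc4ccc5ccc(C(=N)N)cc5c4)c3c2)CC1` is a new compound in which the change 2-carbamoylethyl in place of sec-butyl on an aromatic carbon is made. Within the data shown here, the only measured step, from compound 1 to compound 2, swaps one small alkyl group for a slightly larger one and left the number essentially unchanged; it says little about introducing a chain that carries a hydrogen-bond donor and acceptor. Among the measured compounds shown here, with no closer precedent, the expectation for compound 3 is a modest step of a 1.5-fold higher number from compound 2 to compound 3 (0.18 log units; within the scatter), probably toward a higher number, with a wide range. Compound 3 is therefore estimated at 15 nM in this assay, plausibly between 4 nM and 60 nM.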

Compound 3, inhibition constant: 4.4 nM
Compound 3: the middle estimate sits 3.4-fold (0.53 log units) above what was measured; low and high end bracket the measured number.
By their numbers in this assay, from the lowest: compounds 3, 1 and 2 (each within the scatter of the next, the first and the last beyond it).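

In this assay, among these compounds, the aromatic carbon between two ring nitrogen atoms accepts 2-carbamoylethyl with no loss, whereas the earlier compounds carried only the branched alkyl groups isopropyl and sec-butyl there, with no hydrogen-bond donor or acceptor. Replacing sec-butyl gives a modest change beyond the scatter, a 2.3-fold lower number from compound 2 to compound 3 (0.36 log units; beyond the scatter), while replacing isopropyl gives a 1.3-fold lower number from compound 1 to compound 3 (0.11 log units; within the scatter), which is within the scatter, so compound 1 and compound 3 cannot be told apart. No evidence is available to explain how the chain achieves this.

From the compounds shown here alone, it remains open whether the amide matters or whether an unbranched chain alone would do, which an unbranched butyl chain at this carbon could test. A carboxylic acid, an amine or a longer amide-bearing chain in the same place would show how much this position tolerates.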